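Aryl swap on the amine carbon of compound 1

The compounds below may be only part of what the source reports. "The series", "measured", "known", "first", "only" and "open" are said of these compounds alone.

Measured so far in an assay on isolated protein for binding affinity to C-X-C chemokine receptor type 1 (Homo sapiens); on this read-out lower numbers stand for stronger inhibition and higher numbers for weaker inhibition:
compound 1 `CC[C@@H](Nc1n[s+]([O-])nc1Nc1cccc(C(=O)N(C)C)c1O)c1ccc(C)o1` — 234 nM
compound 2 `Cc1ccc([C@H](Nc2n[s+]([O-])nc2Nc2cccc(C(=O)N(C)C)c2O)C(C)(C)C)o1` — 38 nM
compound 3 `Cc1cc([C@H](Nc2n[s+]([O-])nc2Nc2cccc(C(=O)N(C)C)c2O)C(C)C)oc1C` — 50 nM

Compound 1 stands highest of the three numbers in this assay; compound 3 sits nearer to it, compound 2 furthest. Among the compounds with values here, the only single-point step among them is a 6.2-fold lower number from compound 1 to compound 2 (0.79 log units; beyond the scatter), and it concerns the alkyl on the chain carbon, not the aryl.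

Compound 4 `CC[C@@H](Nc1n[s+]([O-])nc1Nc1cccc(C(=O)N(C)C)c1O)c1ccccc1` differs from compound 1 by phenyl in place of 5-methylfuran-2-yl on a saturated chain carbon bound to a nitrogen on an aromatic ring and a saturated chain carbon. Within the data shown here, no measured step touches this position, so no direction can be drawn from the series; the working assumption is a change within the scatter, with wide uncertainty.

For compound 4 the estimate is 250 nM (range 80 nM to 800 nM). That corresponds to an expected 1.1-fold higher number from compound 1 to compound 4 (0.03 log units; within the scatter).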

Compound 4, inhibition constant: 1220 nM
For compound 4 the middle estimate is 4.9-fold (0.69 log units) below the measured one; measured number above the stated range.
By their numbers in this assay, from the lowest: compounds 2 and 3 (each within the scatter of the next); then compound 1; then compound 4.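

In this assay this position proves sensitive to the aryl group: phenyl in place of 5-methylfuran-2-yl gives a 5.2-fold higher number from compound 1 to compound 4 (0.72 log units; beyond the scatter) and so moves toward weaker inhibition. The change keeps 6 heavy atoms, yet a five-membered aromatic ring with 1 hetero atom gives way to a six-membered aromatic ring of carbon only. Nothing at hand explains the step.

Whether the ring oxygen or the methyl accounts for the difference remains open; unsubstituted furan-2-yl and 5-methylthiophen-2-yl would separate the two. Also open, going by these compounds, is whether the step holds with tert-butyl in place of ethyl.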